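One Stereocentre Flipped in Compound 3

The compounds below may be only part of what the source reports. "The series", "measured", "known", "first", "only" and "open" are said of these compounds alone.

Among the compounds with values here, compound 3 `CCOC(=O)[C@]1(C(=O)Nc2ccccc2Cl)C[C@@H]1c1cc(OC)c(OC)c(OC)c1` gives 19500 nM in a functional assay on K562 cells (Homo sapiens) for cytotoxicity, read by MTT assay, with a stated time of 48 h (a lower number here means a stronger inhibitor, a higher number a weaker inhibitor), and so holds the lowest number measured so far. Compound 2 `CCOC(=O)[C@@]1(C(=O)Nc2ccccc2Cl)C[C@@H]1c1cc(OC)c(OC)c(OC)c1` stands nearest with 49400 nM as its value. Compound 1 `CCOC(=O)[C@]1(C(=O)Nc2ccccc2)C[C@H]1c1cc(OC)c(OC)c(OC)c1` returned only a limit (> 100000 nM) and no number.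

Compound 4 `CCOC(=O)[C@]1(C(=O)Nc2ccccc2Cl)C[C@H]1c1cc(OC)c(OC)c(OC)c1` is still unmeasured. Its relation to compound 3 is the two compounds have the same atoms and bonds and differ only in configuration as drawn: 1 of 2 stereo elements differ; a stereocentre at a saturated ring carbon is drawn R in compound 3 and S in compound 4 with the same atoms and bonds, and a stereocentre at a saturated ring carbon drawn R in compound 3 and S in compound 4.

Within the data shown here, the one measured step of this kind is a 2.5-fold lower number from compound 2 to compound 3 (0.40 log units; beyond the scatter) and it points to the fact that compounds 2 and 3 differ only in the configuration as drawn as its source. That single modest step shows that changing one stereocentre can shift the number measurably. Compound 3 already has the lowest number, so the move away from its configuration is expected to raise the number by a similar amount. The expected change is a 2.3-fold higher number from compound 3 to compound 4 (0.36 log units; beyond the scatter) as an estimate from that one step. For compound 4 the estimated value is 45000 nM with an expected range from 15000 nM to 110000 nM around it.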

Compound 4, half-maximal inhibitory concentration: 20700 nM
Beside the measured number, compound 4's estimate is 2.2-fold (0.34 log units) above it; measured number inside the range.
By their numbers in this assay, from the lowest: compounds 3 and 4 (each within the scatter of the next); then compound 2. At a limit, above all of these: compound 1.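

Inverting this second ring stereocentre gives a 1.1-fold higher number from compound 3 to compound 4 (0.03 log units; within the scatter) in this assay, so on its own it does not separate compound 3 from compound 4, unlike the single inversion measured earlier. Inverting both stereocentres still matters, as the mirror-image pair shows with a 2.4-fold lower number from compound 2 to compound 4 (0.38 log units; beyond the scatter) and leaves a real gap between these two compounds. Compound 1 gave only a limit, and with the same drawn configuration as compound 4, placing chloro in place of hydrogen gives an at least 4.8-fold lower number from compound 1 to compound 4 (0.68 log units; beyond the scatter) as a step that rests on that limit.

Going by these compounds, it remains open whether a methoxy group or a nitrile in place of the chloro would give a similar number. On these data alone, it is also open whether an amine or a carboxylic acid in place of the ethyl ester would change how much these stereocentres matter.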